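The source may hold more compounds than are shown below. What is called first, only, known or untested is meant among the compounds shown, and "the series" means these compounds.

Working notes on the thiazolyl ketone series, three compounds measured and one open.

Compound 1 `Cc1nc(-c2ccc(Cl)cc2)sc1C(=O)CSc1nc(-c2ccc(Cl)c(Cl)c2)c(C#N)c(=O)[nH]1` gives 36.5% in a functional assay on U-87MG ATCC cells for antiproliferative activity against U-87 MG (Homo sapiens), read by MTT assay, with a stated time of 48 h, tested at 100 uM; a higher number here means a weaker effect of the compound at the concentration tested, a lower number a stronger effect. Compound 2 `Cc1nc(-c2ccc(Cl)cc2)sc1C(=O)CSc1nc(N)c(C#N)c(-c2ccc(Cl)cc2)n1` gives 1.65% in this assay. Compound 3 `COc1ccc(-c2nc(SCC(=O)c3sc(-c4ccccc4)nc3C)nc(N)c2C#N)cc1` gives 17.2% in this assay, which places it second highest of the three numbers: its nearest neighbour is compound 2, whose number is lower by a margin beyond the scatter, and the furthest is compound 1, whose number is higher by a margin beyond the scatter. Among the measured compounds shown here, no step between compounds that differ in a single place is available among the measured set, so only the bare values of these pairs can be compared.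

The open compound is compound 4 `COc1ccc(-c2nc(C)c(C(=O)CSc3nc(N)c(C#N)c(-c4ccc(OC)cc4)n3)s2)cc1`. It differs from compound 3 as follows: methoxy in place of hydrogen on an aromatic carbon. The group enters on an aromatic carbon of a six-membered aromatic ring of carbon only, para to a large group; read one bond further out, phenyl becomes 4-methoxyphenyl.

For the measured compounds named here, since no single-point step has been measured, the size of the step in this assay is uncertain. A modest move toward a lower number is expected from compound 3 to compound 4, a number 5.2 percentage points lower from compound 3 to compound 4 (within the scatter), given that compound 2 with a substituted aryl on the thiazole sits at 1.65%, though the move may stay within the scatter. Compound 4 is estimated at 12%, with a range from 3% to 28%.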

Compound 4, a percentage reported as activity, at one concentration (the size of the read-out at that concentration, not a potency): 0.26%
For compound 4 the middle estimate is 11.7 percentage points above the measured one, and the stated range ends above it.
By their numbers in this assay, from the lowest: compounds 4 and 2 (each within the scatter of the next); then compound 3; then compound 1.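

In this assay, among the compounds shown here, the change from phenyl to 4-methoxyphenyl gives a number 16.9 percentage points lower from compound 3 to compound 4 (beyond the scatter), the first step that can be read in a single place. It shows that this position, an aromatic carbon para to a large group, is not silent: methoxy in place of hydrogen moves the read-out beyond the scatter, toward a stronger effect at the concentration tested, and hydrogen is not needed there for the effect to be kept. Nothing among the data available bears on why the number falls with this change.

One group at one position cannot show whether the step follows from methoxy itself or would appear with any substituent, so a hydroxy, ethoxy or dimethylamino group on the same aromatic carbon would be the informative comparison. Whether the step holds on a different core remains open, and because the read-out comes from a single concentration, the compounds shown give no potency.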